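Acetyl on the indole nitrogen: a step without a baseline

The compounds below may be only part of what the source reports. "The series", "measured", "known", "first", "only" and "open" are said of these compounds alone.

Measured compounds:
Compound 1 `COc1cc(OC)cc(/C(=C\c2cn(C(C)=O)c3ccc(OCc4ccccc4)cc23)C(=O)O)c1` gives 26100 nM in a functional assay on LNCaP cells (Homo sapiens) for cytotoxicity, read by MTT assay, with a stated time of 72 h; on this read-out higher numbers stand for weaker inhibition and lower numbers for stronger inhibition.
Compound 2 `COc1cc(/C(=C\c2cn(C(C)=O)c3ccc(OCc4ccccc4)cc23)C(=O)O)cc(OC)c1OC` gives 59600 nM in this assay.
Compound 3 `O=C(O)/C(=C/c1c[nH]c2ccc(OCc3ccccc3)cc12)c1ccccc1` gives "not determined" (no result reported) in this assay, that is, no result is reported for it.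

Compound 3 stands on no number at all: its result in this assay was not determined, so there is nothing to place it against compound 1 or compound 2. Compound 4 `CC(=O)n1cc(/C=C(/C(=O)O)c2ccccc2)c2cc(OCc3ccccc3)ccc21` differs from compound 3 by the change (acetyl in place of hydrogen on an aromatic nitrogen), on an aromatic nitrogen of a five-membered aromatic ring that is part of a fused system of two rings.

Going by the values given here, the one measured step, a 2.3-fold higher number from compound 1 to compound 2 (0.36 log units; beyond the scatter), concerns a methoxy on an aromatic carbon, not an acetyl on a nitrogen, so it does not bear directly on the move from compound 3 to compound 4. It does show that, within the acetyl-bearing core shared by compound 1 and compound 2, a single change on the aromatic ring shifts the number in this assay only modestly. With no baseline for compound 3, no direction can be given for the step.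

Compound 4 carries the same acetyl as compound 1, and its value in this assay is therefore expected near 22000 nM, with a range from 6000 nM to 80000 nM.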

Compound 4, half-maximal inhibitory concentration: > 100000 nM
Compound 4 was reported as a limit; the forecaster's own chance of this, stated with the estimate: 20%; middle value at least 4.5-fold (0.65 log units) away from the limit.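

In this assay, compound 4 gives a limit of the assay, not a number: the limit of > 100000 nM in this assay, at which 1 of the 4 values shown sits. The phenyl compound therefore adds what the earlier pair could not show, a change at the aryl group on the double-bonded chain carbon with the acetyl kept on the aromatic nitrogen, and with phenyl in place of 3,5-dimethoxyphenyl the result is an at least 3.8-fold higher number from compound 1 to compound 4 (0.58 log units; beyond the scatter). With phenyl in place of 3,4,5-trimethoxyphenyl the result is an at least 1.6-fold higher number from compound 2 to compound 4 (0.22 log units; that floor lies within the scatter), a floor within the scatter that fixes no order, so among these three acetyl compounds the number does not follow the count of methoxy groups in one direction, and compound 1 has the lowest number.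

On these data alone, the step from compound 3 to compound 4 cannot be read, as one end has no result and the other is a limit, so what acetyl in place of hydrogen does on the aromatic nitrogen stays open. Also open, as far as these compounds go, is whether a hydroxyl or an amine on the phenyl ring of compound 4, or a longer acyl chain on that nitrogen, would give a number below the limit.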